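A few compounds are considered here, and "the series" means these few. Any claim that something is new, unique, unknown or untested is made for them only; others in the source may bear on it.

Of the compounds shown here, three sharing one core have been measured in an ADME assay on Vero 76 cells (Chlorocebus sabaeus) for cytotoxicity, read by crystal violet staining, with a stated time of 96 h; a lower number here means that less compound is tolerated, a higher number that more compound is tolerated. Compound 1 `Fc1ccccc1NC(=S)Nc1cccc(C(F)(F)F)c1` gives 64000 nM in this assay. Compound 2 `CCCCc1ccc(NC(=S)Nc2cccc(C(F)(F)F)c2)c(C)c1` gives 18000 nM in this assay. Compound 3 `FC(F)(F)c1cccc(NC(=S)Nc2ccc(I)cc2)c1` gives 9500 nM in this assay, the lowest of the three numbers: its distance from compound 2 lies within the scatter, while its distance from compound 1 is beyond it, as the step of a 6.7-fold lower number from compound 1 to compound 3 (0.83 log units; beyond the scatter) shows. Compound 4 `FC(F)(F)c1cccc(NC(=S)Nc2ccccc2)c1` differs from compound 3 by hydrogen in place of iodo on an aromatic carbon, on an aromatic carbon of a six-membered aromatic ring of carbon only. Going by the values given here, no measured step removes iodo alone. Among the compounds with values here, the only step that touches that ring, a 6.7-fold lower number from compound 1 to compound 3 (0.83 log units; beyond the scatter), exchanged the whole ring and was modest, with the number falling as 4-iodophenyl entered. Compound 4 keeps the ring and loses only the iodo, so the number is expected to rise again, by less than that step. Compound 4 is expected to give 25000 nM, within 9000 nM to 70000 nM, in this assay. This corresponds to an expected step of a 2.6-fold higher number from compound 3 to compound 4 (0.42 log units; beyond the scatter).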

Compound 4, half-maximal cytotoxic concentration: 39000 nM
Beside the measured number, compound 4's estimate is 1.6-fold (0.19 log units) below it; the measured number falls inside the stated range.
By their numbers in this assay, from the lowest: compounds 3 and 2 (each within the scatter of the next); then compounds 4 and 1 (each within the scatter of the next).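

In this assay, a 4.1-fold higher number from compound 3 to compound 4 (0.61 log units; beyond the scatter) is modest, and it ties a change beyond the scatter to the iodo alone, at a place para to a large group, which the earlier whole-ring exchange could not do. With a 1.6-fold lower number from compound 1 to compound 4 (0.22 log units; within the scatter) inside the scatter, hydrogen in place of fluoro gives no readable change, so among these compounds the iodo is the one substituent whose exchange for hydrogen shifts the number beyond the scatter. Nothing available bears on the cause of this step.

The compounds shown leave open whether this shift is particular to iodo or would also follow from a bromo, a methoxy or an amine at the same place. They also leave open whether iodo would shift the number similarly on another aromatic carbon of that ring.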